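Acetyl for vinyloxy on the core of compound 1

This account rests on a few compounds, and the source may have more. Where it says the series, first, only, none or still open, it means among the compounds named here.

Three compounds on the shared core have numbers in a functional assay on CHO cells for agonist activity at Alpha-2B adrenergic receptor (Homo sapiens); a lower number here means that less compound is needed, a higher number that more compound is needed for the effect. Compound 1 `C=COc1ccccc1OC(C)C1=NCCN1` gives 3160 nM and stands second highest of the three; compound 2 `C=CCc1cccc(CC=C)c1OC(C)C1=NCCN1` gives 501 nM, and compound 3 `COc1ccccc1OC(C)C1=NCCN1` gives 100000 nM. Among the measured compounds shown here, the one single-point step, a 32-fold higher number from compound 1 to compound 3 (1.50 log units; beyond the scatter), shows that shortening the group on the ring oxygen of compound 1 to methyl costs a great deal in this assay.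

Compound 4 `CC(=O)c1ccccc1OC(C)C1=NCCN1` is not yet measured. It differs from compound 1 as follows: acetyl in place of vinyloxy on an aromatic carbon. For the measured compounds named here, no measured step exchanges an oxygen-linked group for a carbon-linked one, so the step from compound 1 to compound 3 only shows that this position is sensitive, not in which direction acetyl will move the number. Compound 2 carries a different set of substituents and gives no direct guide either.

The expectation for compound 4 is therefore centred near compound 1 with a wide range: compound 4 is estimated at 5000 nM, between 1000 nM and 30000 nM. The step this estimate implies, a 1.6-fold higher number from compound 1 to compound 4 (0.20 log units; within the scatter), is expected to be modest.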

Compound 4, half-maximal effective concentration: 295 nM
For compound 4 the middle estimate is 17-fold (1.23 log units) above the measured one; the measured number lies below the stated range.
By their numbers in this assay, from the lowest: compounds 4 and 2 (each within the scatter of the next); then compound 1; then compound 3.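

In this assay acetyl in place of vinyloxy gives an 11-fold lower number from compound 1 to compound 4 (1.03 log units; beyond the scatter) and is the first change shown to lower the number at this aromatic carbon, where the earlier step only raised it. Acetyl in place of methoxy gives a 340-fold lower number from compound 3 to compound 4 (2.53 log units; beyond the scatter) and shows that this one position spans a wider range than the earlier compounds revealed. Vinyloxy and acetyl match in heavy atoms, double bonds and hydrogen-bond acceptors, so these counts do not separate two groups whose numbers clearly differ, and no supporting measurement bears on the reason for the gap.

Still open, from the compounds shown here alone, is whether the lower number extends to other carbon-linked groups at this position, such as propanoyl, a carboxylic acid or a primary amide. Also open, going by these compounds, is how acetyl behaves alongside the substituents of compound 2.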